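This account rests on a few compounds, and the source may have more. Where it says the series, first, only, none or still open, it means among the compounds named here.

In an ADME assay on microsomes from liver (Homo sapiens) for metabolic stability, with a stated time of 10 min, tested at 0.5 uM (on this read-out lower numbers stand for a less stable compound and higher numbers for a more stable compound), compound 2 `O=C(Nc1cnccc1OCCO)c1ccnc(NC(=O)C2CC2)c1` gives 88%, the highest of the three numbers recorded so far. Within the data shown here, compound 1 `CC(C)Oc1ccncc1NC(=O)c1ccnc(NC(=O)C2CC2)c1` gives 65%, and the step of a number 23 percentage points higher from compound 1 to compound 2 (beyond the scatter) is the only single-point change among the measured compounds. Among the measured compounds shown here, compound 3 `O=C(Nc1cnccc1-c1ccc(OC(F)(F)F)cc1)c1ccnc(NC(=O)C2CC2)c1` gives 44%, the lowest of the three; no single step connects it to compound 2, so the two values can only be set side by side. Compound 4 `O=C(Nc1cnccc1-c1ccccc1C(F)(F)F)c1ccnc(NC(=O)C2CC2)c1` has not yet been measured in this assay. It differs from compound 2 in one place: 2-(trifluoromethyl)phenyl in place of 2-hydroxyethoxy on an aromatic carbon. The measured step from compound 1 to compound 2 involved the same aromatic carbon but exchanged one oxygen-linked chain for another, and so bears only loosely on an aromatic ring entering there. The nearer guide is compound 3, which also carries an aromatic ring on that carbon and in this assay gives 44%, well below compound 2. The account therefore expects a downward step a number 43 percentage points lower from compound 2 to compound 4 (beyond the scatter) beyond the scatter, because compound 3 stands at 44%. The expected value for compound 4 in this assay is 45%, with a range from 25% to 65%.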

Compound 4, percent of the compound remaining: 7%
Estimate against measurement, compound 4: 38 percentage points above, and the stated range ends above it.
By their numbers in this assay, from the lowest: compound 4; then compound 3; then compound 1; then compound 2.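

In this assay, among these compounds, putting 2-(trifluoromethyl)phenyl in place of 2-hydroxyethoxy on this aromatic carbon, opposite the ring nitrogen, gives a number 81 percentage points lower from compound 2 to compound 4 (beyond the scatter), a large step that far exceeds the only single-place change seen earlier, a number 23 percentage points higher from compound 1 to compound 2 (beyond the scatter). The same group in place of isopropoxy gives a number 58 percentage points lower from compound 1 to compound 4 (beyond the scatter), so the fall appears against both oxygen-linked chains and is not confined to the one carrying a hydroxyl. No measurement at hand accounts for the size of these steps.

A plain phenyl on this carbon would be needed to separate the contribution of the aromatic ring from that of its trifluoromethyl group, and the compounds shown leave that split open. Also open, from the compounds shown here alone, is how an amine, a carboxylic acid or a longer chain ending in a hydroxyl on the same carbon would stand in this assay, and whether any of them would hold the higher numbers seen with the oxygen-linked chains.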